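Chloro for hydrogen on the phenyl of compound 1

This account rests on a few compounds, and the source may have more. Where it says the series, first, only, none or still open, it means among the compounds named here.

Compound 1 `C/C(=N\NC(=O)/C(C#N)=C/c1ccccc1)c1c(O)c2ccc(O)cc2oc1=O` and compound 2 `COc1ccc(/C=C(\C#N)C(=O)N/N=C(\C)c2c(O)c3ccc(O)cc3oc2=O)cc1OC` share one core and differ in the phenyl at the end of the chain. In a functional assay on MCF7 cells (Homo sapiens) for cytotoxicity, read by MTT assay, with a stated time of 24 h (a higher number here means a weaker inhibitor, a lower number a stronger inhibitor), compound 1 gives 19200 nM, and compound 2 gives 14400 nM. The step of a 1.3-fold lower number from compound 1 to compound 2 (0.12 log units; within the scatter) is within the scatter, so compound 1 stands at the highest of the two numbers, with compound 2 not separable from it.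

Compound 3 `C/C(=N\NC(=O)/C(C#N)=C/c1ccccc1Cl)c1c(O)c2ccc(O)cc2oc1=O` differs from compound 1 by chloro in place of hydrogen on an aromatic carbon. Within the data shown here, the single measured step, a 1.3-fold lower number from compound 1 to compound 2 (0.12 log units; within the scatter), also altered the phenyl of compound 1, though at different carbons and with different groups; it gives the sole point of comparison, and it did not move the number beyond the scatter. Nothing in the data suggests a change of different size for a chloro at the place described. Compound 3 is therefore expected to give 17000 nM in this assay, with a range from 8000 nM to 36000 nM. That estimate means a step of a 1.1-fold lower number from compound 1 to compound 3 (0.05 log units; within the scatter), expected to stay within the scatter.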

Compound 3, half-maximal inhibitory concentration: 8880 nM
Estimate against measurement, compound 3: 1.9-fold (0.28 log units) above; measured number inside the range.
By their numbers in this assay, from the lowest: compounds 3, 2 and 1 (each within the scatter of the next, the first and the last beyond it).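

In this assay, among these compounds, the step of a 2.2-fold lower number from compound 1 to compound 3 (0.33 log units; beyond the scatter) is the first change on the phenyl of compound 1 that passes the scatter, and it takes only one heavy atom, a chloro on an aromatic carbon ortho to a large group. The size of this step is modest, and the result does not set the 2-chlorophenyl apart from the 3,4-dimethoxyphenyl, for the step of a 1.6-fold lower number from compound 2 to compound 3 (0.21 log units; within the scatter) stays within the scatter, so the two substituted phenyls cannot be ranked against each other. No measurement shown here bears on what lies behind the step from hydrogen to chloro at this place.

The compounds shown leave open whether this step belongs to chloro itself or would come with any group on that aromatic carbon, and a fluoro, a methoxy or an amine at the same place would tell these readings apart. They also leave open whether the same chloro would move the number on the 3,4-dimethoxyphenyl of compound 2, and whether a larger step can be reached at this position at all.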